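Swapping the aryl group on the ring nitrogen of compound 2

A few compounds are considered here, and "the series" means these few. Any claim that something is new, unique, unknown or untested is made for them only; others in the source may bear on it.

This series was tested in a functional assay on MCF7 cells (Homo sapiens) for antiproliferative activity, read by MTT assay, with a stated time of 72 h; on this read-out lower numbers stand for stronger inhibition and higher numbers for weaker inhibition. Compound 1, with the structure `CC(Nc1nc(N)nc2ccc(-c3cnn(C)c3)cc12)c1c(Cl)ccc(F)c1Cl`, gives 2870 nM in this assay. Compound 3, with the structure `CC(Nc1ncnc2ccc(-c3cnn(C4CCNCC4)c3)cc12)c1c(Cl)ccc(F)c1Cl`, gives 2650 nM. Compound 2, with the structure `C#Cc1cccc(Nc2ncnc3ccc(-c4cnn(C)c4)cc23)c1`, gives 11400 nM, the highest of the three numbers; its gaps to compound 1 and to compound 3 both lie beyond the usual scatter of repeated measurements.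

The next compound is compound 4, with the structure `Cn1cc(-c2ccc3ncnc(Nc4ccc(F)c(Cl)c4)c3c2)cn1`. It differs from compound 2 in one place: 3-chloro-4-fluorophenyl in place of 3-ethynylphenyl on a nitrogen on an aromatic ring. Both groups sit on the same nitrogen, and both contain one six-membered aromatic ring of carbon only; only the substituents on that ring change.

Going by the values given here, no measured pair in this set shows such a swap, so nothing in the data fixes the size of the step. The expectation is a modest move toward a lower number, a step from compound 2 to compound 4 of a 1.4-fold lower number from compound 2 to compound 4 (0.15 log units; within the scatter), though a step within the scatter would not surprise. Compound 4 is therefore estimated at 8000 nM, with a range from 2500 nM to 25000 nM.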

Compound 4, half-maximal inhibitory concentration: 52200 nM
Estimate against measurement, compound 4: 6.5-fold (0.81 log units) below; measured number outside the range, above it.
By their numbers in this assay, from the lowest: compounds 3 and 1 (each within the scatter of the next); then compound 2; then compound 4.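

In this assay, the group on this nitrogen turns out to matter: the swap gives a 4.6-fold higher number from compound 2 to compound 4 (0.66 log units; beyond the scatter) and so moves the number well past the usual scatter. The group that leaves and the group that enters have the same count of heavy atoms and the same six-membered aromatic ring of carbon only, so a change in the substituents on that ring is enough to produce a step of this size. Nothing measured here explains the step.

A single swap cannot separate the part played by the chlorine, the fluorine and the lost ethynyl group. The compounds shown also leave open where a plain phenyl, or a phenyl carrying only a methoxy group or an amine, would fall on this nitrogen.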